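Changing the Group on Sulfur in a Growth Inhibitor

The compounds below may be only part of what the source reports. "The series", "measured", "known", "first", "only" and "open" are said of these compounds alone.

For the measured compounds named here, in a functional assay on DU-145 cells (Homo sapiens) for inhibition, read by trypan blue exclusion, with a stated time of 96 h (on this read-out lower numbers stand for stronger inhibition of growth and higher numbers for weaker inhibition of growth), two compounds have numbers so far. Compound 1 (`COc1ccccc1/C=C(/SCc1ccc(F)cc1)C(=O)c1ccc(Br)cc1`) gives 10000 nM and compound 2 (`COc1ccc(/C=C(/Sc2ccc(C)cc2)C(=O)c2ccc(Br)cc2)cc1`) gives 50000 nM as the higher of the two numbers, which means weaker inhibition of growth. Compound 3 (`COc1ccc(/C=C(/SCc2ccc(F)cc2)C(=O)c2ccc(Br)cc2)cc1`) differs from compound 2 in one place, with 4-fluorobenzyl in place of 4-methylphenyl on a sulfur. Going by the values given here, no measured pair shows this change alone, so any forecast is rough. Compound 1 also carries 4-fluorobenzyl on a sulfur, and its 10000 nM is the reason to expect a lower number here. In this assay the expected change is a 5.0-fold lower number from compound 2 to compound 3 (0.70 log units; beyond the scatter) toward stronger inhibition, a step beyond the scatter. For compound 3 the estimate is 10000 nM (expected range 2500 nM to 40000 nM).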

Compound 3, concentration for 50% growth inhibition: 50000 nM
Compound 3: middle estimate off by 5.0-fold (0.70 log units), on the low side; the whole stated range lies below it.
By their numbers in this assay, from the lowest: compound 1; then compounds 2 and 3 (each within the scatter of the next).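

In this assay, 4-fluorobenzyl in place of 4-methylphenyl on the sulfur gives no change at the digits printed from compound 2 to compound 3 (within the scatter), so with 4-methoxyphenyl held constant, this change on the sulfur does not shift the number beyond the scatter. With 4-fluorobenzyl held constant, 4-methoxyphenyl in place of 2-methoxyphenyl on the double-bonded chain carbon gives a 5.0-fold higher number from compound 1 to compound 3 (0.70 log units; beyond the scatter), so among these compounds the lower number goes with the 2-methoxyphenyl group and not with 4-fluorobenzyl alone. Nothing available here explains either step.

On these data alone, it remains open whether a different kind of group on the sulfur, such as a longer chain or a chain ending in an amine, would change the number. As far as these compounds go, it is also open whether 4-methylphenyl and 4-fluorobenzyl on the sulfur would still match with 2-methoxyphenyl in the molecule.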